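Piperazin-1-yl in Place of a Pyrrolidine on Two Cores

The source may hold more compounds than are shown below. What is called first, only, known or untested is meant among the compounds shown, and "the series" means these compounds.

Of the compounds shown here, three have been tested in a functional assay on V79 cells (Cricetulus griseus) for cytotoxicity, read by colony formation; on this read-out higher numbers stand for weaker inhibition and lower numbers for stronger inhibition. Compound 1 `CNCC1(C)CCN(c2c(F)cc3c(=O)c(C(=O)O)cn(C4CC4)c3c2Cl)C1` gives 23 ug/mL, and compound 3 `O=C(O)c1cn(C2CC2)c2c(Cl)c(N3CCNCC3)c(F)cc2c1=O` gives 43 ug/mL. The two differ in one place: piperazin-1-yl in place of 3-methyl-3-((methylamino)methyl)pyrrolidin-1-yl on an aromatic carbon That change gave a 1.9-fold higher number from compound 1 to compound 3 (0.27 log units; within the scatter). Compound 2 `CNCC1(C)CCN(c2nc3c(cc2F)c(=O)c(C(=O)O)cn3C2CC2)C1` carries the same side group as compound 1 on a different core; how the two cores differ is not broken down here. In this assay compound 2 gives 58 ug/mL.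

Compound 4 `O=C(O)c1cn(C2CC2)c2nc(N3CCNCC3)c(F)cc2c1=O` has not yet been measured. It relates to compound 2 as compound 3 relates to compound 1: piperazin-1-yl in place of 3-methyl-3-((methylamino)methyl)pyrrolidin-1-yl on an aromatic carbon This is the same kind of change, though the surroundings differ: in compound 2 the group sits on a six-membered aromatic ring with one nitrogen, next to the ring nitrogen and ortho to a fluoro group, while in compound 1 it sits on a ring of carbon only, ortho to a chloro group and ortho to a fluoro group.

Because the earlier step was a 1.9-fold higher number from compound 1 to compound 3 (0.27 log units; within the scatter), a similar, modest rise in the number is expected from compound 2 to compound 4, about a 1.5-fold higher number from compound 2 to compound 4 (0.17 log units; within the scatter). Compound 4 is therefore estimated at 85 ug/mL, with a likely range from 40 ug/mL to 180 ug/mL.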

Compound 4, half-maximal inhibitory concentration: 120 ug/mL
Beside the measured number, compound 4's estimate is 1.4-fold (0.15 log units) below it; measured number inside the range.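

In this assay, piperazin-1-yl in place of 3-methyl-3-((methylamino)methyl)pyrrolidin-1-yl gave a 2.1-fold higher number from compound 2 to compound 4 (0.32 log units; beyond the scatter), which means weaker inhibition on this read-out. Set beside the matching step on the core of compound 1, this step cannot be told apart from it: the same change on two cores in this assay, a 1.9-fold higher number (0.27 log units; within the scatter) from compound 1 to compound 3 and a 2.1-fold higher number (0.32 log units; beyond the scatter) from compound 2 to compound 4, 1.1-fold (0.04 log units) apart, within the scatter of two such steps

For the compounds shown here, the change therefore behaves alike on these two cores, although only the step on the core of compound 2 lies beyond the scatter, and two pairs cannot show that it would hold on a third core or reveal what lies behind it.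

The compounds shown carry only these two side groups, so it remains open how a simple open-chain diamine, or a piperazine with a methyl group on its nitrogen, would compare in this assay. On these data alone, it is also open whether the step would stay similar on a core with an ethyl group in place of the cyclopropyl group.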